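A few compounds are considered here, and "the series" means these few. Any claim that something is new, unique, unknown or untested is made for them only; others in the source may bear on it.

Measured compounds:
compound 1 `CCCNCC(=O)N1N=C(c2cc3ccccc3oc2=O)CC1c1ccccc1`, 7270 nM in a functional assay on PC-3 cells (Homo sapiens) for cytotoxicity, read by MTT assay, with a stated time of 48 h; a higher number here means a weaker inhibitor, a lower number a stronger inhibitor
compound 2 `O=C(CNC1CC1)N1N=C(c2cc3ccccc3oc2=O)CC1c1ccccc1`, 28500 nM in this assay

Among the measured compounds shown here, compound 2 gives the highest of the two numbers so far in this assay; its nearest neighbour is compound 1, which sits one step away. For the measured compounds named here, the only measured step, a 3.9-fold higher number from compound 1 to compound 2 (0.59 log units; beyond the scatter), shows how far a small change on the amine nitrogen moved the number.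

Compound 3 `CCN(CC)C1CCN(CC(=O)N2N=C(c3cc4ccccc4oc3=O)CC2c2ccccc2)CC1` is not yet measured. It differs from compound 2 in one place: 4-(diethylamino)piperidin-1-yl in place of cyclopropylamino on a saturated chain carbon bound to a carbonyl carbon. Going by the values given here, no measured step covers this exchange, so the step from compound 1 to compound 2 is the only guide to how this part of the molecule behaves, and it was modest.

On that basis compound 3 is expected to land near compound 2, with a chance of a somewhat lower number, an estimated step of a 1.9-fold lower number from compound 2 to compound 3 (0.28 log units; within the scatter). Compound 3 is therefore estimated at 15000 nM in this assay, within a range from 4000 nM to 60000 nM.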

Compound 3, half-maximal inhibitory concentration: 26100 nM
Estimate against measurement, compound 3: 1.7-fold (0.24 log units) below, within the range that was stated.
By their numbers in this assay, from the lowest: compound 1; then compounds 3 and 2 (each within the scatter of the next).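

In this assay, replacing cyclopropylamino with 4-(diethylamino)piperidin-1-yl on the saturated chain carbon bound to a carbonyl carbon gives a 1.1-fold lower number from compound 2 to compound 3 (0.04 log units; within the scatter), so a far larger group, with a six-membered ring and no hydrogen-bond donor, leaves the reading indistinguishable from that of compound 2. Set against propylamino, the same exchange gives a 3.6-fold higher number from compound 1 to compound 3 (0.56 log units; beyond the scatter), which places two very different groups together on the same side of compound 1 and leaves propylamino as the only one of the three with a clearly lower number. Nothing available explains why these two groups read alike or why propylamino stands apart.

On these data alone, it remains open whether a longer straight chain such as butylamino, or a branched one such as isopropylamino, would stay close to compound 1 or join compounds 2 and 3. Nor do these compounds show how a morpholine or a piperazine at this carbon would read, or whether a simple dimethylamino group would behave like propylamino or like the ring-bearing groups.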